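The source may report more compounds than this note shows. Statements on the series, on what has been measured and on what is new or still open speak of the compounds shown alone.

Measured so far, all in a functional assay on DU-145 cells (Homo sapiens) for antiproliferative activity, read by sulforhodamine B assay, with a stated time of 72 h; on this read-out higher numbers stand for weaker inhibition and lower numbers for stronger inhibition: compound 1 `Cc1ccc(C(/C=C/c2ccc(F)cc2)=N\Nc2nncc3ccccc23)cc1` gives 5.6 nM, compound 2 `Clc1ccc(C(/C=C/c2ccccc2)=N\Nc2nncc3ccccc23)cc1` gives 4.6 nM, and compound 3 `Cc1cc(C)nc(NS(=O)(=O)c2ccc(Nc3nncc4ccccc34)cc2)n1` gives 7.8 nM.

Compound 3 has the highest of the three numbers, yet its gaps to compound 1 and to compound 2 both lie within the scatter, so no order among the three can be claimed. Compound 4 `O=S(=O)(Nc1ncccn1)c1ccc(Nc2nncc3ccccc23)cc1` differs from compound 3 in one place: pyrimidin-2-yl in place of 4,6-dimethylpyrimidin-2-yl on a sulfonamide nitrogen. Within the data shown here, no measured pair shows this change, so the data give no step to lean on. In this assay only a small step is expected, with no direction that should clearly exceed the scatter. For compound 4 the estimate is 10 nM, within 4 nM to 25 nM. The implied step, a 1.3-fold higher number from compound 3 to compound 4 (0.11 log units; within the scatter), is expected to stay within the scatter.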

Compound 4, half-maximal inhibitory concentration: 45 nM
The estimate for compound 4 lay 4.5-fold (0.65 log units) below the measured number; the measured number lies above the stated range.
By their numbers in this assay, from the lowest: compounds 2, 1 and 3 (each within the scatter of the next); then compound 4.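

In this assay, pyrimidin-2-yl in place of 4,6-dimethylpyrimidin-2-yl on the sulfonamide nitrogen gives a 5.8-fold higher number from compound 3 to compound 4 (0.76 log units; beyond the scatter), a step beyond the scatter. This shows that the number responds to the substituents on this ring, even though the ring itself stays the same and the change lies far out on the sulfonamide group. Nothing available bears on why the number rises.

From the compounds shown here alone, it remains open whether a single methyl on the pyrimidine would keep the lower number, or whether ethyl, methoxy or an amine could replace the methyl groups. Going by these compounds, it is also open whether a pyridin-2-yl ring would be tolerated on this nitrogen.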